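Pentyloxy in Place of 2-Methoxyethoxy: Expected Cytotoxicity

A few compounds are considered here, and "the series" means these few. Any claim that something is new, unique, unknown or untested is made for them only; others in the source may bear on it.

Compound 1, `COCCOc1nc(N)nc2c1ncn2/C=C1/CC1(CO)CO`, in an ADME assay on Akata cells (Homo sapiens) for cytotoxicity, with a stated time of 7 days (on this read-out higher numbers stand for lower toxicity in this test and lower numbers for higher toxicity in this test), gives only a limit, > 20000 nM.
Compound 2, `CCCNc1nc(N)nc2c1ncn2/C=C1/CC1(CO)CO`, in this assay gives only a limit, > 24000 nM.
Compound 3, `CC(C)CNc1nc(N)nc2c1ncn2/C=C1/CC1(CO)CO`, in this assay gives only a limit, > 24000 nM.

Compound 1 stands at a limit of the assay, namely (the limit of > 20000 nM in this assay, at which 1 of the 3 values shown sits). Compound 2 and compound 3 stand together at another limit, (the limit of > 24000 nM in this assay, at which 2 of the 3 values shown sit). For the measured compounds named here, none of the three measured values is an actual number, so no compound can be placed above or below another on this read-out.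

Compound 4, `CCCCCOc1nc(N)nc2c1ncn2/C=C1/CC1(CO)CO`, differs from compound 1 in one place: propyl in place of methoxy on a saturated chain carbon, two bonds along the chain from an oxygen on an aromatic ring. The chain on the oxygen of the shared core grows by one carbon and loses its ether oxygen.

The measured steps that touch the same part of the core are a step that the two limits leave unreadable from compound 1 to compound 2 and a step that the two limits leave unreadable from compound 1 to compound 3; between the two amines lies a step that the two limits leave unreadable from compound 2 to compound 3. In every case both ends sit at a limit, so none of these steps has a readable size. Going by the values given here, there is therefore no measured step that could point to a change in this assay in either direction, and the most that can be said is that every change tried at this position has left the compound at a limit.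

On that basis compound 4 is expected to behave like compound 1, with a value estimated at 22000 nM, in a range from 8000 nM to 60000 nM. The expected step is a step that the limit leaves unreadable from compound 1 to compound 4, and a limit rather than a number is the likeliest outcome.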

Compound 4, half-maximal cytotoxic concentration: > 20000 nM
Compound 4 ended at the assay's limit; the forecaster's own chance of this, stated with the estimate: 75%; the middle value does not contradict the limit.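

Compound 4, like compound 1, compound 2 and compound 3, ends at a limit of this assay, so the steps from those three compounds to compound 4 cannot be read. The compounds shown leave open whether pentyloxy, 2-methoxyethoxy, propylamino and isobutylamino differ at all on this read-out.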